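The source may hold more compounds than are shown below. What is called first, only, known or untested is meant among the compounds shown, and "the series" means these compounds.

Measured so far:
- compound 1, `O=C(NO)c1ccc(-c2cn([C@@H]3C[C@@H](C(=O)O)N(Cc4ccccc4)C3)nn2)cc1`: < 10%
- compound 2, `O=C(NO)c1ccc(-c2cn([C@@H]3C[C@@H](CO)N(Cc4ccccc4)C3)nn2)cc1`: < 10%
- compound 3, `O=C(NO)c1cccc(-c2cn([C@@H]3C[C@H](C(=O)O)N(Cc4ccccc4)C3)nn2)c1`: < 10%

In an assay on Sf9 cells for inhibition of histone deacetylase 11 (Homo sapiens), read by fluorescence, tested at 0.5 uM (on this read-out higher numbers stand for more inhibition at the one concentration tested (going by the name of the read-out) and lower numbers for less inhibition), compound 1 gives only a limit, < 10%. Compound 2 likewise gives only a limit in this assay, < 10%. Compound 3 also stays at a limit, < 10%. Because of the limit of < 10% in this assay, at which 3 of the 3 values shown sit, none of the three measured compounds shows a readable amount of inhibition at the single concentration tested.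

Compound 2 arises from compound 1 by one change, (hydroxymethyl in place of carboxy on a saturated ring carbon). The step that change made in this assay is a step that the two limits leave unreadable from compound 1 to compound 2, since both ends are limits rather than numbers.

Compound 3 shares its atoms with compound 1 but has them joined differently; the difference between the two cores is not broken down here. The unmeasured compound 4, `O=C(NO)c1cccc(-c2cn([C@@H]3C[C@H](CO)N(Cc4ccccc4)C3)nn2)c1`, stands to compound 3 as compound 2 stands to compound 1: the change is hydroxymethyl in place of carboxy on a saturated ring carbon, and its surroundings are described in the same words as before, so it is the same change.

Since compound 3 gives < 10%, and the same change left compound 2 at a limit as well, compound 4 is expected to remain at the limit too. The step from compound 3 to compound 4 is estimated as a step that the limit leaves unreadable from compound 3 to compound 4. Compound 4 is therefore expected to give about 5%, most likely between 0% and 15%, and most probably reported only as a limit.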

Compound 4, a percentage reported as inhibition, at one concentration (the size of the read-out at that concentration, not a potency): < 10%
Compound 4 was reported as a limit; the forecaster's own chance of this, stated with the estimate: 80%; the middle value is on the limit's open side.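

In this assay no size can be given for the change from compound 3 to compound 4, because both ends are limits rather than numbers: the limit of < 10% in this assay, at which 4 of the 4 values shown sit. The compounds shown leave open whether carboxy and hydroxymethyl differ at all in the inhibition they allow, and what change to the shared core would bring a compound up to a readable value.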